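An Aryl Swap on the Ring Nitrogen of Compound 1

This account rests on a few compounds, and the source may have more. Where it says the series, first, only, none or still open, it means among the compounds named here.

Compound 1 `CC(C)(C)c1conc1N1C(=O)CSC1c1cccc(C(=O)NCCCCc2ccccc2)c1` was tested in a functional assay on HOS-TE85 cells (Homo sapiens) for inhibition, read by CCK-8 assay, with a stated time of 72 h; on this read-out higher numbers stand for weaker inhibition and lower numbers for stronger inhibition. Compound 1 gives > 1000 nM, which is a limit of the assay rather than a number, as the limit of > 1000 nM in this assay, at which 1 of the 3 values shown sits, shows. Two further compounds on the shared core were also measured: compound 2 `CC1SC(c2cccc(C(=O)NCCCCc3ccc(Cl)cc3)c2)N(c2cccc(C3CC3)c2)C1=O` gives 932 nM in this assay, and compound 3 `CCOC(=O)c1sc(N2C(=O)CSC2c2cccc(C(=O)NCCCCn3cccn3)c2)nc1C` gives 430 nM. Compound 4 `C#Cc1cccc(N2C(=O)CSC2c2cccc(C(=O)NCCCCc3ccccc3)c2)c1` has not yet been measured; it differs from compound 1 by a group of 8 heavy atoms (8 carbon; one six-membered aromatic ring of carbon only) in place of a group of 9 heavy atoms (7 carbon, 1 nitrogen, 1 oxygen; one five-membered aromatic ring with 2 hetero atoms), on an amide-type nitrogen in a ring. For the measured compounds named here, no measured step matches this change. Since compound 2 and compound 3 return numbers rather than limits, a move toward stronger inhibition of roughly an at least 1.6-fold lower number from compound 1 to compound 4 (0.22 log units; that floor lies within the scatter) is expected for compound 4, beyond the usual scatter. Compound 4 is therefore estimated at 600 nM, in a range from 200 nM to 3000 nM.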

Compound 4, half-maximal inhibitory concentration: 149 nM
Compound 4: the middle estimate sits 4.0-fold (0.60 log units) above what was measured, and the stated range ends above it.
By their numbers in this assay, from the lowest: compound 4; then compound 3; then compound 2. At a limit, above all of these: compound 1.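

On the amide-type nitrogen in the ring, 3-ethynylphenyl in place of the group with the five-membered aromatic ring gives an at least 6.7-fold lower number from compound 1 to compound 4 (0.82 log units; beyond the scatter). For the compounds shown here, this is the first step on the shared core that changes one place only, and it shows that the group on this nitrogen alone can shift the read-out beyond the scatter. The true size of the step stays unknown because compound 1 stands at a limit: the limit of > 1000 nM in this assay, at which 1 of the 4 values shown sits.

On these data alone, whether the triple bond itself matters remains open. So does how a plain phenyl, or a nitrile in place of the ethynyl, would compare on this nitrogen.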